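The source may hold more compounds than are shown below. What is called first, only, known or untested is meant among the compounds shown, and "the series" means these compounds.

Compound 1 `COc1ccccc1-n1nncc1CN1C(=O)C2(C(C#N)=C(N)Oc3c2c2nc4ccccc4nc2c2ccccc32)c2ccccc21` carries a 2-methoxyphenyl group on an aromatic nitrogen of the shared core. In an ADME assay on HUVEC cells (Homo sapiens) for antiproliferative activity, read by MTT assay, with a stated time of 48 h (on this read-out higher numbers stand for weaker inhibition and lower numbers for stronger inhibition), compound 1 gives only the assay limit of > 50000 nM. Compound 2 `CCOc1ccccc1-n1nncc1CN1C(=O)C2(C(C#N)=C(N)Oc3c2c2nc4ccccc4nc2c2ccccc32)c2ccccc21` has a methyl in place of hydrogen on a saturated chain carbon bound to an oxygen on an aromatic ring, and in this assay compound 2 also reaches only the limit, > 50000 nM. Compound 3 `Cc1ccc(-n2nncc2CN2C(=O)C3(C(C#N)=C(N)Oc4c3c3nc5ccccc5nc3c3ccccc43)c3ccccc32)c(C)c1` bears a 2,4-dimethylphenyl instead. In this assay compound 3 likewise gives only the limit, > 50000 nM. Compound 3 thus stands where every value shown stands, at the limit of > 50000 nM in this assay, at which 3 of the 3 values shown sit. The steps a step that the two limits leave unreadable from compound 1 to compound 2, a step that the two limits leave unreadable from compound 1 to compound 3 and a step that the two limits leave unreadable from compound 2 to compound 3 have no readable size; each joins two limits. Compound 4 `Cc1ccc(Cl)cc1-n1nncc1CN1C(=O)C2(C(C#N)=C(N)Oc3c2c2nc4ccccc4nc2c2ccccc32)c2ccccc21` is not yet measured and differs from compound 3 in that (5-chloro-2-methylphenyl in place of 2,4-dimethylphenyl on an aromatic nitrogen). Among the compounds with values here, no measured step gives a readable size for a change of this kind, so no shift beyond the scatter is expected in this assay. Compound 4 is therefore estimated at 50000 nM, with a range from 20000 nM to 200000 nM, most likely again only a limit. The expected step is a number no higher from compound 3 to compound 4 (the limit leaves the size open).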

Compound 4, half-maximal inhibitory concentration: > 50000 nM
Compound 4: only a limit was reported (the forecaster's own chance of this, stated with the estimate: 85%); the middle value sits exactly at the limit.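

Compound 4 also stops at a limit, so no step joining it to compound 1, compound 2 or compound 3 can be read in this assay; every compound now stands at one value: the limit of > 50000 nM in this assay, at which 4 of the 4 values shown sit.

What the compounds shown leave open is how strongly any of them inhibits, since none gives an actual number.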